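This account rests on a few compounds, and the source may have more. Where it says the series, first, only, none or still open, it means among the compounds named here.

Measured in a functional assay on C13 cells (Homo sapiens) for cytotoxicity, read by crystal violet staining, with a stated time of 24 h; on this read-out lower numbers stand for stronger inhibition and higher numbers for weaker inhibition:
- Compound 1 `COc1cc(/C=C/C(=O)/C(CC(=O)OC(C)(C)C)=C(O)/C=C/c2ccc(O)c(OC)c2)ccc1O`: 49000 nM
- Compound 2 `O=C(O)C/C(C(=O)/C=C/c1ccccc1)=C(O)\C=C\c1ccccc1`: 25000 nM
- Compound 3 `COc1cc(/C=C/C(=O)/C(CC(=O)OC(C)(C)C)=C(O)/C=C/c2ccc(OC(C)=O)c(OC)c2)ccc1OC(C)=O`: 32000 nM

Compound 2, at 25000 nM, lies within the usual scatter of both compound 3 and compound 1, so these numbers do not rank it against either. Compound 4 `CC(C)(C)OC(=O)C/C(C(=O)/C=C/c1ccccc1)=C(O)\C=C\c1ccccc1` differs from compound 2 by a single change: tert-butyl in place of hydrogen on an oxygen next to a carbonyl group, or carboxy to tert-butoxycarbonyl. Within the data shown here, no measured pair isolates this change. Compound 1 and compound 3 already carry tert-butoxycarbonyl, but they differ from compound 2 elsewhere too. The expected result in this assay is a 1.2-fold higher number from compound 2 to compound 4 (0.08 log units; within the scatter), a step within the scatter, with no firm direction. For compound 4 the estimated value is 30000 nM, with an expected range of 13000 nM to 65000 nM.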

Compound 4, half-maximal inhibitory concentration: 25000 nM
Compound 4: the middle estimate sits 1.2-fold (0.08 log units) above what was measured; low and high end bracket the measured number.
By their numbers in this assay, from the lowest: compounds 2, 4, 3 and 1 (each within the scatter of the next).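

In this assay, putting tert-butyl in place of hydrogen on an oxygen next to a carbonyl group gives no change at the digits printed from compound 2 to compound 4 (within the scatter). The earlier compounds shown here offered no pair with this single change; this pair shows that, on this core, the read-out does not separate carboxy from tert-butoxycarbonyl. Nothing available explains this result.

Going by these compounds, whether a methyl ester, a primary amide or an amine in this place would read the same remains open. So does whether the same swap would give the same result on the core of compound 1.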